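A few compounds are considered here, and "the series" means these few. Any claim that something is new, unique, unknown or untested is made for them only; others in the source may bear on it.

Measured so far in an ADME assay on Karpas-1106P cells (Homo sapiens) for cytotoxicity; on this read-out higher numbers stand for an effect only at larger amounts of compound and lower numbers for an effect already at smaller amounts:
- Compound 1 `Cc1ccc(S(=O)(=O)N[C@@H](CC(=O)NC(C)(C)C)C(=O)NCCNC(=O)c2cccc(C(C)C)c2)cc1`: > 11100 nM
- Compound 2 `Cc1ccc(S(=O)(=O)N[C@@H](CC(=O)NC(C)(C)C)C(=O)NCCNC(=O)c2ccccc2F)cc1`: > 11100 nM

Compound 2 has no exact number here, only a limit of the assay, > 11100 nM. Compound 1 also has only a limit, > 11100 nM. Together they give (the limit of > 11100 nM in this assay, at which 2 of the 2 values shown sit).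

The next compound, compound 3 `Cc1ccc(S(=O)(=O)N[C@@H](CC(=O)NC(C)(C)C)C(=O)NCCNC(=O)c2cc(Cl)ccc2Cl)cc1`, keeps the shared core but has 2,5-dichlorophenyl in place of 2-fluorophenyl on a carbonyl carbon.

One measured step changes the group at this same place: a step that the two limits leave unreadable from compound 1 to compound 2. It provides neither a size nor a direction, so no clear shift can be predicted. The limit of compound 2, > 11100 nM, remains the only anchor, and compound 3 is expected to stay close to it, probably again as a limit.

The estimated change is a step that the limit leaves unreadable from compound 2 to compound 3. For compound 3, the estimated value is 15000 nM, with an expected range from 6000 nM to 35000 nM.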

Compound 3, half-maximal effective concentration: > 11100 nM
Compound 3 gave a limit, no number; the forecaster's own chance of this, stated with the estimate: 80%; the middle value lies beyond the limit too.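

No step among compound 1, compound 2 and compound 3 can be read in this assay, since each result is a limit and not a number: the limit of > 11100 nM in this assay, at which 3 of the 3 values shown sit.

As far as these compounds go, what stays open is the amount of each compound needed for an effect, and whether changing the group on the carbonyl carbon alters it.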